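Shortening the chain on the aromatic nitrogen of compound 2

This account rests on a few compounds, and the source may have more. Where it says the series, first, only, none or still open, it means among the compounds named here.

Compound 1 `COc1cc(C(=O)O)ccc1Cc1cn(C2CCCC2)c2ccc(NC(=O)OC3CCCC3)cc12`: 53 nM
Compound 2 `CCCn1cc(Cc2ccc(C(=O)O)cc2OC)c2cc(NC(=O)CC3CCCC3)ccc21`: 84 nM

In an assay on lung parenchyma (Cavia porcellus) for displacement of a labelled ligand from cysteinyl leukotriene receptor (Homo sapiens) (a higher number here means a weaker inhibitor, a lower number a stronger inhibitor), compound 1 gives 53 nM, and compound 2 gives 84 nM. Of the two numbers, that of compound 2 is the higher one, but its distance from compound 1 is within the scatter, so the two cannot be ordered.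

Compound 3 `CCn1cc(Cc2ccc(C(=O)O)cc2OC)c2cc(NC(=O)CC3CCCC3)ccc21` differs from compound 2 in one place: hydrogen in place of methyl on a saturated chain carbon, two bonds along the chain from an aromatic nitrogen, that is, propyl to ethyl on the aromatic nitrogen. For the measured compounds named here, no step between measured compounds speaks to this change, and nothing among the two measured compounds suggests a shift of any size beyond the scatter. The expected step from compound 2 to compound 3 is therefore small, a 1.2-fold higher number from compound 2 to compound 3 (0.08 log units; within the scatter), in no firm direction.

In this assay compound 3 is estimated at 100 nM, within a range of 40 nM to 250 nM.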

Compound 3, inhibition constant: 71 nM
Beside the measured number, compound 3's estimate is 1.4-fold (0.15 log units) above it, and the stated range covers the measured number.
By their numbers in this assay, from the lowest: compounds 1, 3 and 2 (each within the scatter of the next).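

In this assay, propyl to ethyl on the aromatic nitrogen comes to a 1.2-fold lower number from compound 2 to compound 3 (0.07 log units; within the scatter), so compound 2 and compound 3 cannot be ordered. For the compounds shown here, this is the first direct reading at this position: with the rest of compound 2 unchanged, hydrogen in place of methyl on a saturated chain carbon, two bonds along the chain from an aromatic nitrogen, produces no shift beyond the scatter. No independent measurement is available to explain this result.

As far as these compounds go, whether the same holds for a still shorter methyl on the aromatic nitrogen, for a hydrogen there or for a longer butyl chain remains open. The compounds shown also leave open how a hydroxyl or an amine at the end of this chain would read.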